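Methyl on the shared core: compound 3 to compound 4

This account rests on a few compounds, and the source may have more. Where it says the series, first, only, none or still open, it means among the compounds named here.

compound 1 `COc1cc(/C=C/C(=O)/C=C/c2nc3ccccc3n2C)ccc1O`: 3700 nM
compound 2 `COc1cc(/C=C/C(=O)/C=C/c2nc3cc(Cl)ccc3n2C)ccc1O`: 4400 nM
compound 3 `COc1ccc(/C=C/C(=O)/C=C/c2nc3ccccc3n2C)cc1O`: 3600 nM

All three values come from a functional assay on MCF7 cells (Homo sapiens) for cytotoxicity, read by MTT assay, with a stated time of 48 h; on this read-out lower numbers stand for stronger inhibition and higher numbers for weaker inhibition. Compound 3 at 3600 nM lies within the scatter of both other compounds, so the three cannot be ranked. Compound 4 `COc1ccc(/C=C/C(=O)/C=C/c2nc3cc(C)ccc3n2C)cc1O` differs from compound 3 by one change: methyl in place of hydrogen on an aromatic carbon. Going by the values given here, no measured compound carries this methyl. The nearest measured step is a 1.2-fold higher number from compound 1 to compound 2 (0.08 log units; within the scatter), chloro in place of hydrogen on an aromatic carbon, and it stays within the scatter. On that evidence, no step beyond the scatter is expected in this assay. The expected step is a 1.1-fold higher number from compound 3 to compound 4 (0.02 log units; within the scatter). The estimated value for compound 4 is 3800 nM, with an expected range of 2200 nM to 6500 nM.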

Compound 4, half-maximal inhibitory concentration: 3600 nM
Compound 4: middle estimate off by 1.1-fold (0.02 log units), on the high side, within the range that was stated.
By their numbers in this assay, from the lowest: compounds 3, 4, 1 and 2 (each within the scatter of the next).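

In this assay, methyl in place of hydrogen on an aromatic carbon gives no change at the digits printed from compound 3 to compound 4 (within the scatter), so a carbon substituent on this ring leaves the number within the scatter. Alongside a 1.2-fold higher number from compound 1 to compound 2 (0.08 log units; within the scatter), with chloro in place of hydrogen on an aromatic carbon, this makes two single changes on the shared core, neither beyond the scatter. No measurement at hand accounts for this flat result. From the compounds shown here alone, whether an amine, a carboxylic acid or a longer chain at this carbon would move the number beyond the scatter remains open.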